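Fluoromethyl in Place of Methyl: Compound 2 to Compound 3

This account rests on a few compounds, and the source may have more. Where it says the series, first, only, none or still open, it means among the compounds named here.

This account concerns two measured compounds and a third awaiting measurement in a functional assay on the whole organism (aorta) with Rattus norvegicus as the target; a lower number here means a smaller maximal response, a higher number a larger maximal response. Compound 2, `CC1(C)C=C(C(=O)NCCC#N)c2cc([N+](=O)[O-])ccc2O1`, is the stronger of the two measured compounds: in this assay compound 2 gives 73.1%. Compound 1, `CC1(CF)C=C(/C(S)=N\CCC#N)c2cc([N+](=O)[O-])ccc2O1`, gives 59.6% in this assay, and the gap between the two values lies beyond the usual scatter of the method, so compound 2 stands clearly at the top of the numbers available. Within the data shown here, no single-point step between the two measured compounds is recorded, since compound 1 and compound 2 differ in more than one place.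

Compound 3, `CC1(CF)C=C(C(=O)NCCC#N)c2cc([N+](=O)[O-])ccc2O1`, is the unmeasured compound. It differs from compound 2 by a single change: fluoro in place of hydrogen on a saturated chain carbon bound to a saturated ring carbon. Methyl becomes fluoromethyl, nothing else moves.

Because compound 1, which also carries the fluoromethyl group, gives 59.6%, the writer expects a modest loss in maximal response, with the step estimated as a number 8.1 percentage points lower from compound 2 to compound 3 (within the scatter). Compound 3 is accordingly expected to reach about 65%, within a range from 50% to 80%.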

Compound 3, intrinsic activity: the largest response reached, in percent of the reference agonist's: 71%
For compound 3 the middle estimate is 6 percentage points below the measured one, within the range that was stated.
By their numbers in this assay, from the lowest: compound 1; then compounds 3 and 2 (each within the scatter of the next).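

In this assay the exchange of methyl for fluoromethyl gives a number 2.1 percentage points lower from compound 2 to compound 3 (within the scatter), so at this saturated chain carbon bound to a saturated ring carbon the fluoro in place of hydrogen leaves no change that the assay can tell from scatter. Among these compounds, compound 3 also gives the first single-place comparison on the double-bonded ring carbon, where the group holding oxygen in place of the group holding sulfur gives a number 11.4 percentage points higher from compound 1 to compound 3 (beyond the scatter) and the step is modest. With fluoromethyl present in both compounds of that step, the fluoromethyl group alone does not account for the low number of compound 1, and among these three compounds the clear difference goes with the exchange on the double-bonded ring carbon.

From the compounds shown here alone, whether a trifluoromethyl group, a hydroxymethyl group or an ethyl chain at the same place would also leave the maximal response in this range remains open. The compounds shown also leave open how an amine or a carboxylic acid on the double-bonded ring carbon would compare with the two groups seen there, and the data shown offer no measurement that explains either step.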